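The compounds below may be only part of what the source reports. "The series", "measured", "known", "first", "only" and "open" are said of these compounds alone.

Series notes. Compound 1 `Cc1ccccc1-n1nncc1CN1C(=O)C2(C(C#N)=C(N)Oc3c2c2nc4ccccc4nc2c2ccccc32)c2ccccc21` and compound 2 `N#CC1=C(N)Oc2c(c3nc4ccccc4nc3c3ccccc23)C12C(=O)N(Cc1cnnn1-c1ccccc1Br)c1ccccc12` belong to the same set as compound 3 `CCc1ccccc1-n1nncc1CN1C(=O)C2(C(C#N)=C(N)Oc3c(N)cc4nc5ccccc5nc4c32)c2ccccc21` and differ from one another in the group carried on the five-membered aromatic ring with 3 nitrogen. In an ADME assay on L02 cells (Homo sapiens) for antiproliferative activity, read by MTT assay, with a stated time of 48 h (a higher number here means a weaker inhibitor, a lower number a stronger inhibitor), compound 1 gives > 50000 nM, which is a limit of the assay and not a number. In this assay compound 2 gives > 50000 nM, likewise a limit. The step that the two limits leave unreadable from compound 1 to compound 2 cannot be read because of the limit of > 50000 nM in this assay, at which 2 of the 3 values shown sit. For the measured compounds named here, compound 3 gives 22900 nM in this assay, and it is the only number in the set.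

Compound 4 `Cc1cc(C)cc(-n2nncc2CN2C(=O)C3(C(C#N)=C(N)Oc4c(N)cc5nc6ccccc6nc5c43)c3ccccc32)c1` is to be measured in this assay. It differs from compound 3 by 3,5-dimethylphenyl in place of 2-ethylphenyl on an aromatic nitrogen. Going by the values given here, the one measured step that touches the group on that ring nitrogen, a step that the two limits leave unreadable from compound 1 to compound 2, is unreadable, so no measured step gives the size of a change at that position, and no other comparison in the set bears on it. Nothing beyond the scatter is therefore expected for the estimated step of a 1.1-fold higher number from compound 3 to compound 4 (0.04 log units; within the scatter). Compound 4 is expected to give about 25000 nM in this assay, with a range from 10000 nM to 60000 nM.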

Compound 4, half-maximal inhibitory concentration: > 50000 nM
Compound 4 gave a limit, no number (the forecaster's own chance of this, stated with the estimate: 35%); at least 2.0-fold (0.30 log units) between middle value and limit.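

Working from the core of compound 3, placing 3,5-dimethylphenyl in place of 2-ethylphenyl on the aromatic nitrogen gives the first readable step at this position in this assay: an at least 2.1-fold higher number from compound 3 to compound 4 (0.33 log units; beyond the scatter). The two groups have the same heavy-atom count, all carbon, with no hydrogen-bond donors or acceptors and no net charge, so the series now shows that rearranging these carbons on the phenyl ring alone can shift the reading beyond the scatter. As far as these compounds go, the value for compound 4 is a limit and not a number, so the true size of the step stays unknown and only its direction and minimum size can be read, because the reading stops at the same ceiling as most of the set: the limit of > 50000 nM in this assay, at which 3 of the 4 values shown sit.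

For the compounds shown here, the step from compound 1 to compound 2 still cannot be read, and the single change from compound 3 to compound 4 does not separate the loss of the ethyl group from the gain of the two methyl groups. Also open, from the compounds shown here alone, is how the core of compound 3 would read with an amine, a carboxylic acid or a chain longer than ethyl on this phenyl ring.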